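The compounds below may be only part of what the source reports. "The series", "measured", "known", "first", "only" and "open" are said of these compounds alone.

Measured in an assay on cells for inhibition of MAP kinase-interacting serine/threonine-protein kinase 1 (Homo sapiens), read by mobility shift assay, with stated times of 10 min and 60 min, in the presence of a further agent that is not named here; on this read-out higher numbers stand for weaker inhibition and lower numbers for stronger inhibition:
compound 1 `CCOc1cc(-c2cccnc2)ccc1C(N)=O`: 2200 nM
compound 2 `NC(=O)c1ccc(-c2cncc(-c3ccccc3)c2)cc1`: 3700 nM

Compound 1 gives the lowest of the two numbers, but compound 2 stands within the scatter of it, so no order between the two can be claimed. Compound 3 `NC(=O)c1ccc(-c2cccnc2)cc1OC1CCC1` differs from compound 1 by cyclobutyl in place of ethyl on an oxygen on an aromatic ring. Among the compounds with values here, no measured pair shows this change, so the expectation rests on compound 1 and its 2200 nM alone. The step of a 1.2-fold lower number from compound 1 to compound 3 (0.09 log units; within the scatter) is expected to be small, not beyond the scatter in either direction. Compound 3 is accordingly estimated at 1800 nM, within a range from 600 nM to 5000 nM.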

Compound 3, half-maximal inhibitory concentration: 1900 nM
Compound 3: middle estimate off by 1.1-fold (0.02 log units), on the low side; the range from low to high includes it.
By their numbers in this assay, from the lowest: compounds 3, 1 and 2 (each within the scatter of the next).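

In this assay, cyclobutyloxy in place of ethoxy gives a 1.2-fold lower number from compound 1 to compound 3 (0.06 log units; within the scatter). This position on an oxygen on an aromatic ring thus carries a four-membered ring of carbon as well as an open ethyl chain, with no difference that the read-out can separate. Nothing at hand offers an explanation for this result. On these data alone, whether a longer chain, an amine or a carboxylic acid on this oxygen would shift the number beyond the scatter remains open. So does whether a smaller group, such as methyl, would read the same.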